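This account rests on a few compounds, and the source may have more. Where it says the series, first, only, none or still open, it means among the compounds named here.

Measured so far:
compound 1 `COc1ccc2ncc(S(=O)(=O)c3ccc(Cl)cc3)c(N3CCC(C)CC3)c2c1`: 91%
compound 2 `CC1CCN(c2c(S(=O)(=O)c3ccc(Cl)cc3)cnc3ccc(F)cc23)CC1`: 80%

In an assay on isolated protein for displacement of a labelled ligand from metabotropic glutamate receptor 5 (Homo sapiens), with a stated time of 60 min, tested at 1 uM (on this read-out higher numbers stand for more inhibition at the one concentration tested (going by the name of the read-out) and lower numbers for less inhibition), compound 1 gives 91% and compound 2 gives 80%; compound 2 is the lower of the two, the step of a number 11 percentage points lower from compound 1 to compound 2 (beyond the scatter) lying beyond the scatter. Compound 3 `Cc1ccc2ncc(S(=O)(=O)c3ccc(Cl)cc3)c(N3CCC(C)CC3)c2c1` is not yet measured; it differs from compound 2 as methyl in place of fluoro on an aromatic carbon. Going by the values given here, no measured step exchanges methyl for fluoro. Among the compounds with values here, the only step to hand, a number 11 percentage points lower from compound 1 to compound 2 (beyond the scatter), shows a modest shift from a change at this carbon, so a step of similar or smaller size is expected, leaning upward because compound 1 with a different group at that carbon gives 91%. Compound 3 is expected to give 85%, range 70% to 95%. The expected step is a number 5 percentage points higher from compound 2 to compound 3 (within the scatter).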

Compound 3, a percentage reported as inhibition, at one concentration (the size of the read-out at that concentration, not a potency): 79%
Compound 3: the middle estimate sits 6 percentage points above what was measured; low and high end bracket the measured number.
By their numbers in this assay, from the lowest: compounds 3 and 2 (each within the scatter of the next); then compound 1.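

In this assay, exchanging fluoro for methyl at this aromatic carbon gives a number 1 percentage points lower from compound 2 to compound 3 (within the scatter), so these two groups cannot be told apart here. Methyl in place of methoxy gives a number 12 percentage points lower from compound 1 to compound 3 (beyond the scatter), which matches the earlier fluoro comparison and leaves methoxy as the only one of the three groups set apart from the others at this carbon. Nothing available explains that separation. Going by these compounds, whether a longer chain such as ethoxy would read like methoxy remains open, as does the reading of an amine or a carboxylic acid at this carbon.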